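The source may report more compounds than this note shows. Statements on the series, on what has been measured and on what is new or still open speak of the compounds shown alone.

Measured so far:
compound 1, `CC(=O)c1ccc(/C=C2\CCCN=C2c2cccnc2)cc1`: 4490 nM
compound 2, `Cc1cc(O)cc(C)c1/C=C1\CCCN=C1c1cccnc1`: 670 nM
compound 3, `COc1cc(OC)c(/C=C2\CCCN=C2c2cccnc2)c(OC)c1`: 60 nM

In an assay on membranes from brain for displacement of a labelled ligand from Neuronal acetylcholine receptor; alpha4/beta2 (Rattus norvegicus), with a stated time of 3 h (on this read-out higher numbers stand for weaker inhibition and lower numbers for stronger inhibition), compound 1 gives the highest of the three numbers. Compound 2 sits beyond the scatter below it, and compound 3 lies furthest away, also beyond the scatter. Compound 4, `CSc1ccc(/C=C2\CCCN=C2c2cccnc2)cc1`, is not yet measured. It differs from compound 1 in one place: methylsulfanyl in place of acetyl on an aromatic carbon. Among the measured compounds shown here, no step between two measured compounds covers this exchange of acetyl for methylsulfanyl on an aromatic carbon, so the size of the step must be judged from the spread of the series alone. A moderate move toward a lower number is expected, as the step of a 3.0-fold lower number from compound 1 to compound 4 (0.48 log units; beyond the scatter) is estimated. A result within the scatter of compound 1 would not be surprising. For compound 4 the estimate is 1500 nM, with a range from 400 nM to 6000 nM.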

Compound 4, inhibition constant: 900 nM
Estimate against measurement, compound 4: 1.7-fold (0.22 log units) above; the measured number falls inside the stated range.
By their numbers in this assay, from the lowest: compound 3; then compounds 2 and 4 (each within the scatter of the next); then compound 1.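

Among the compounds shown here, on the aromatic carbon para to a large group, methylsulfanyl in place of acetyl gives the first step that changes one place only: a 5.0-fold lower number from compound 1 to compound 4 (0.70 log units; beyond the scatter) is modest but beyond the scatter. This position therefore responds to the exchange, although leaving and entering groups carry the same count of hydrogen-bond acceptors. Nothing available accounts for the step. Open, going by these compounds, is how an amine, a carboxylic acid or a longer chain at this carbon would compare with methylsulfanyl and acetyl.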